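Amide nitrogen: phenyl to 4-methoxybenzyl, compound 3 to compound 4

This account rests on a few compounds, and the source may have more. Where it says the series, first, only, none or still open, it means among the compounds named here.

Compound 3 `COc1ccc(Cl)cc1N(CC(=O)Nc1ccccc1)S(=O)(=O)c1ccccc1` gives only a limit in a functional assay on SH-SY5Y cells (Homo sapiens), read by MTT assay, with a stated time of 24 h (on this read-out higher numbers stand for an effect only at larger amounts of compound and lower numbers for an effect already at smaller amounts), namely > 20000 nM. Compound 1 `COc1ccc(Cl)cc1N(CC(=O)Nc1ccc(C(F)(F)F)cc1)S(=O)(=O)c1ccccc1` gives 3750 nM in this assay, and compound 2 `COc1ccc(NC(=O)CN(c2cc(Cl)ccc2OC)S(=O)(=O)c2ccccc2)cc1` gives 16200 nM in this assay. The measured steps are a 4.3-fold higher number from compound 1 to compound 2 (0.64 log units; beyond the scatter), an at least 5.3-fold higher number from compound 1 to compound 3 (0.72 log units; beyond the scatter) and an at least 1.2-fold higher number from compound 2 to compound 3 (0.09 log units; that floor lies within the scatter); the two steps ending at compound 3 can only be given as floors because of the limit of > 20000 nM in this assay, at which 1 of the 3 values shown sits.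

Compound 4 `COc1ccc(CNC(=O)CN(c2cc(Cl)ccc2OC)S(=O)(=O)c2ccccc2)cc1` differs from compound 3 by 4-methoxybenzyl in place of phenyl on an amide-type nitrogen. For the measured compounds named here, none of the measured steps changes the amide nitrogen itself; the nearest is the methoxy step an at least 1.2-fold higher number from compound 2 to compound 3 (0.09 log units; that floor lies within the scatter), whose floor stays within the scatter, and the other two steps concern a trifluoromethyl on the aromatic carbon, not a benzyl on the nitrogen. The expectation for compound 4 is therefore no step beyond the scatter, a number no higher from compound 3 to compound 4 (the limit leaves the size open), with a fair chance that compound 4 again returns only a limit. Compound 4 is estimated at 20000 nM in this assay, between 7000 nM and 60000 nM.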

Compound 4, half-maximal effective concentration: > 20000 nM
Compound 4 ended at the assay's limit; the forecaster's own chance of this, stated with the estimate: 50%; the middle value sits exactly at the limit.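

Replacing phenyl with 4-methoxybenzyl on the amide nitrogen gives a step that cannot be read, because compound 3 and compound 4 both stand at a limit: the limit of > 20000 nM in this assay, at which 2 of the 4 values shown sit. The comparison with the 4-(trifluoromethyl)phenyl amide is readable in this assay, with an at least 5.3-fold higher number from compound 1 to compound 4 (0.72 log units; beyond the scatter), so 4-methoxybenzyl at this position does not reach the level of the 4-(trifluoromethyl)phenyl group. The comparison with the 4-methoxyphenyl amide gives an at least 1.2-fold higher number from compound 2 to compound 4 (0.09 log units; that floor lies within the scatter), a floor that does not separate the two groups.

Going by these compounds, whether 4-(trifluoromethyl)benzyl or a longer chain such as phenethyl on the amide nitrogen would return a value inside the range of this assay remains open. On these data alone, the shared core is the same in all four compounds, so the effect of an amine or a carboxylic acid on it is also open.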